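Cytotoxicity notes: aryl substitution on the saturated ring carbon

The source may hold more compounds than are shown below. What is called first, only, known or untested is meant among the compounds shown, and "the series" means these compounds.

Measured so far in an ADME assay on Vero cells (Chlorocebus sabaeus) for cytotoxicity, read by sulforhodamine B assay, with a stated time of 3 days; a lower number here means that less compound is tolerated, a higher number that more compound is tolerated:
compound 1 `CC1=C(C(=O)Nc2ccc(Cl)cc2)C(c2cccc([N+](=O)[O-])c2)C(C(=O)Nc2ccc(Cl)cc2)=C(C)N1`, 26 ug/mL
compound 2 `CC1=C(C(=O)Nc2ccc(Cl)cc2)CC(C(=O)Nc2ccc(Cl)cc2)=C(C)N1`, 40 ug/mL

Among the measured compounds shown here, compound 2 stands at 40 ug/mL in this assay; the only other number, that of compound 1, lies within the scatter of it, the step being a 1.5-fold higher number from compound 1 to compound 2 (0.19 log units; within the scatter).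

Compound 3 `CC1=C(C(=O)Nc2ccc(Cl)cc2)C(c2ccccc2O)C(C(=O)Nc2ccc(Cl)cc2)=C(C)N1` differs from compound 2 by 2-hydroxyphenyl in place of hydrogen on a saturated ring carbon. For the measured compounds named here, the one measured step that bears on this position is a 1.5-fold higher number from compound 1 to compound 2 (0.19 log units; within the scatter), the removal of an aryl group from the same saturated ring carbon, and that step stayed within the scatter. Reading it in reverse, placing an aryl group back on that carbon is expected to move this assay little, if at all, so a step of a 1.3-fold lower number from compound 2 to compound 3 (0.12 log units; within the scatter) is expected, with no clear direction beyond the scatter. For compound 3 the estimate in this assay is 30 ug/mL, in the range 15 ug/mL to 60 ug/mL.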

Compound 3, half-maximal cytotoxic concentration: 62 ug/mL
Compound 3: the middle estimate sits 2.1-fold (0.32 log units) below what was measured, outside the stated range (above it).
By their numbers in this assay, from the lowest: compounds 1, 2 and 3 (each within the scatter of the next, the first and the last beyond it).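

In this assay, the saturated ring carbon now gives a step beyond the scatter: a 2.4-fold higher number from compound 1 to compound 3 (0.38 log units; beyond the scatter) follows the exchange of 3-nitrophenyl for 2-hydroxyphenyl, a modest separation between two aryl groups at one position. Placing 2-hydroxyphenyl on that carbon in place of hydrogen gives a 1.6-fold higher number from compound 2 to compound 3 (0.19 log units; within the scatter) and stays within the scatter, so this aryl group is not separated from hydrogen, and the one step beyond the scatter comes from the exchange of one aryl group for another. Nothing available here accounts for the difference between the two aryl groups.

The two aryl groups differ both in their substituent and in where it sits on the phenyl ring, and these two changes remain unseparated. Also open, on these data alone, is how a phenyl ring bearing an amine or a carboxylic acid, or a longer alkyl chain in place of the aryl group, would fall at this carbon.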